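One Hydroxy Fewer: What to Expect for Compound 4

The compounds below may be only part of what the source reports. "The series", "measured", "known", "first", "only" and "open" are said of these compounds alone.

Compound 1 `Cc1c(C(=O)N/N=C\c2ccc(O)c(O)c2O)oc2cccc(O)c12`: >= 40000 nM, a limit of the assay rather than a number.
Compound 2 `Cc1c(C(=O)N/N=C\c2cccc(O)c2)oc2cccc(O)c12`: 17600 nM.
Compound 3 `Cc1c(C(=O)N/N=C\c2cc(Cl)cc(Cl)c2O)oc2cccc(O)c12`: 9590 nM.

All three were tested in a functional assay on PC-3 cells (Homo sapiens) for inhibition; on this read-out lower numbers stand for stronger inhibition and higher numbers for weaker inhibition. For compound 1 the assay reports only a limit, (the limit of >= 40000 nM in this assay, at which 1 of the 3 values shown sits). Of the two actual numbers, compound 2 stands at the higher one, while compound 3 sits within the usual scatter of repeated measurements, so the two cannot be ranked against each other.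

Compound 4 `Cc1c(C(=O)N/N=C\c2ccccc2)oc2cccc(O)c12` has not yet been measured. It differs from compound 2 in a single place: hydrogen in place of hydroxy on an aromatic carbon. For the measured compounds named here, no pair of measured compounds shows this same change, so there is no direct guide to how large its effect might be. With only the scattered picture of compounds 1, 2 and 3 to go on, the hydroxy removal is expected to move the number little, if at all. Compound 4 is therefore estimated at about 20000 nM, somewhere between 8000 nM and 50000 nM. That estimate amounts to an expected step of a 1.1-fold higher number from compound 2 to compound 4 (0.06 log units; within the scatter), no larger than the scatter.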

Compound 4, half-maximal inhibitory concentration: 29200 nM
Beside the measured number, compound 4's estimate is 1.5-fold (0.16 log units) below it, within the range that was stated.
By their numbers in this assay, from the lowest: compounds 3, 2 and 4 (each within the scatter of the next, the first and the last beyond it). At a limit, above all of these: compound 1.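

For the compounds shown here, the change from 3-hydroxyphenyl to phenyl gives a 1.7-fold higher number from compound 2 to compound 4 (0.22 log units; within the scatter) in this assay and so offers the first direct reading of this position. The two compounds cannot be told apart here, so this pair gives no sign that the hydroxy on this aromatic carbon is needed for inhibition in these cells. Compound 1 gives only a limit and not a number, so steps to it cannot be read: the limit of >= 40000 nM in this assay, at which 1 of the 4 values shown sits.

From the compounds shown here alone, this is a single pair, so it remains unknown whether removing the hydroxy would give a similar result on compounds with other substituents. Going by these compounds, it is also open whether a methoxy group or an amine at this position would give a number clearly different from that of compound 2.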